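The compounds below may be only part of what the source reports. "The series", "measured", "known", "first", "only" and "open" are said of these compounds alone.

Measured in a functional assay on SMMC-7721 cells (Homo sapiens) for cytotoxicity, read by MTT assay, with a stated time of 24 h; on this read-out lower numbers stand for stronger inhibition and higher numbers for weaker inhibition:

compound 1, `O=C1/C(=C/c2cccnc2)CN(S(=O)(=O)c2ccc(C(F)(F)F)cc2)C/C1=C\c1ccccc1F`, gives 7900 nM
compound 2, `O=C1/C(=C/c2ccncc2)CN(S(=O)(=O)c2ccc(C(F)(F)F)cc2)C/C1=C\c1ccccc1F`, gives 11100 nM
compound 3, `O=C1/C(=C/c2cccnc2)CNC/C1=C\c1ccccc1C(F)(F)F`, gives 5100 nM

Compound 1 and compound 2 differ in one place, (pyridin-4-yl in place of pyridin-3-yl on a double-bonded chain carbon bound to a double-bonded ring carbon), and this change gave a 1.4-fold higher number from compound 1 to compound 2 (0.15 log units; within the scatter). Compound 3 carries a different core; how the core of compound 3 differs from the core of compound 1 is not broken down here, and the two values lie within the scatter of each other, while compound 2 sits beyond it.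

Compound 4, `O=C1/C(=C/c2ccncc2)CNC/C1=C\c1ccccc1C(F)(F)F`, is not yet measured. It stands to compound 3 as compound 2 stands to compound 1: pyridin-4-yl in place of pyridin-3-yl on a double-bonded chain carbon bound to a double-bonded ring carbon. The place is described in the same words for both pairs, so this is the same change, now made on the core of compound 3.

Among the compounds with values here, for compound 4 in this assay a step of a 1.4-fold higher number from compound 3 to compound 4 (0.14 log units; within the scatter) is expected, placed beside the earlier one, because a 1.4-fold higher number from compound 1 to compound 2 (0.15 log units; within the scatter) is the only measured precedent for this change and it lay within the scatter. Going by these compounds, whether the core of compound 3 carries the change in the same way is untested. Compound 4 is therefore estimated at 7000 nM, with a range from 3500 nM to 14000 nM.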

Compound 4, half-maximal inhibitory concentration: 4500 nM
For compound 4 the middle estimate is 1.6-fold (0.19 log units) above the measured one, and the stated range covers the measured number.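

In this assay, pyridin-4-yl in place of pyridin-3-yl on a double-bonded chain carbon bound to a double-bonded ring carbon, now on the second core, gave a 1.1-fold lower number from compound 3 to compound 4 (0.05 log units; within the scatter). Set against the earlier step, the two cores show no readable difference for this change: the same change on two cores in this assay, a 1.4-fold higher number (0.15 log units; within the scatter) from compound 1 to compound 2 and a 1.1-fold lower number (0.05 log units; within the scatter) from compound 3 to compound 4, 1.6-fold (0.20 log units) apart, within the scatter of two such steps So in these two pairs the change stays within the scatter on both cores and carries over as a step of no readable size, but neither step gives a direction that can be read, and two pairs fix no rule for other cores in the series.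

Still open, going by these compounds, is whether a different group at this place, such as a plain phenyl or a phenyl bearing a carboxylic acid or an amine, would move the number beyond the scatter. Also open is the separate effect of the arylsulfonyl group of compound 1, which no pair shown isolates.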